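Acetylation of the chain hydroxyl on two sulfonamide cores

The source may hold more compounds than are shown below. What is called first, only, known or untested is meant among the compounds shown, and "the series" means these compounds.

Compound 1 `NS(=O)(=O)c1ccc(S(=O)(=O)CCCO)s1` and compound 2 `CC(=O)OCCCS(=O)(=O)c1ccc(S(N)(=O)=O)s1` differ in one place: acetyl in place of hydrogen on an oxygen on a saturated carbon. In a physicochemical assay for acid dissociation, compound 1 gives 8.32 and compound 2 gives 8.05, and the step is a number 0.27 log units lower from compound 1 to compound 2 (within the scatter). Compound 3 `NS(=O)(=O)c1ccc(CCCCCO)cc1` rests on another core; the difference between the core of compound 3 and the core of compound 1 is not broken down here. In this assay compound 3 gives 10.3, the highest of the three numbers, beyond the scatter from compound 1 and from compound 2 alike. Compound 4 `CC(=O)OCCCCCc1ccc(S(N)(=O)=O)cc1` has not been measured. It differs from compound 3 by acetyl in place of hydrogen on an oxygen on a saturated carbon, the same change made from compound 1 to compound 2, at a place described in the same words. The step of a number 0.27 log units lower from compound 1 to compound 2 (within the scatter) lay within the scatter, so for compound 4 a step of similar, small size is expected, a number 0.20 log units lower from compound 3 to compound 4 (within the scatter). Compound 4 is accordingly estimated at 10.1 in this assay, with a range expected from 9.7 to 10.5.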

Compound 4, acid dissociation constant: 10.3
The estimate for compound 4 lay 0.20 log units below the measured number; the measured number falls inside the stated range.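

In this assay the change to acetyl in place of hydrogen on an oxygen on a saturated carbon gives no change at the digits printed from compound 3 to compound 4 (within the scatter), and on the other core the same change gave a number 0.27 log units lower from compound 1 to compound 2 (within the scatter). Both steps lie within the scatter, so on these two cores the change leaves the read-out without a step that can be told from none. This rests on two pairs only and does not show that the same would hold on a further core, at another place or in any other read-out, and nothing shown here gives a reason for either step.

The compounds shown leave open whether a benzoyl group on that oxygen, or an amine or a carboxylic acid in place of the hydroxy, would read the same way. Also open, as far as these compounds go, is how a longer chain on the core of compound 3 would read in this assay.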